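Amide nitrogen substitution in a three-compound series

The source may report more compounds than this note shows. Statements on the series, on what has been measured and on what is new or still open speak of the compounds shown alone.

Measured so far:
compound 1 `COC(=O)c1ccc(/C=C/C(=O)c2cc(OC)ccc2OC)cc1`, 4850 nM
compound 2 `COc1ccc(OC)c(C(=O)/C=C/c2ccc(C(=O)OCc3ccccc3)cc2)c1`, 18000 nM
compound 3 `CCNC(=O)c1ccc(/C=C/C(=O)c2cc(OC)ccc2OC)cc1`, 4180 nM

In a functional assay on PC-3 cells (Homo sapiens) for cytotoxicity, read by MTT assay, with a stated time of 72 h (a lower number here means a stronger inhibitor, a higher number a weaker inhibitor), compound 3 gives the lowest of the three numbers, yet the gap to compound 1 lies within the scatter, so no order between them can be drawn; only compound 2 sits clearly apart, as a 4.3-fold lower number from compound 2 to compound 3 (0.63 log units; beyond the scatter) shows.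

Compound 4 `COc1ccc(OC)c(C(=O)/C=C/c2ccc(C(=O)N(C)C)cc2)c1` differs from compound 3 by dimethylamino in place of ethylamino on a carbonyl carbon. For the measured compounds named here, no measured step touches the amide nitrogen itself. The nearest guides are a 1.2-fold lower number from compound 1 to compound 3 (0.06 log units; within the scatter), which was flat, and a 4.3-fold lower number from compound 2 to compound 3 (0.63 log units; beyond the scatter), where a bulkier group left the carbonyl. Neither speaks directly to exchanging one small amine for another, so a step within the scatter is expected. For compound 4 the expected step is a 1.2-fold higher number from compound 3 to compound 4 (0.08 log units; within the scatter). Compound 4 is therefore estimated at 5000 nM, with a range of 2500 nM to 10000 nM.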

Compound 4, half-maximal inhibitory concentration: 4580 nM
Estimate against measurement, compound 4: 1.1-fold (0.04 log units) above; measured number inside the range.
By their numbers in this assay, from the lowest: compounds 3, 4 and 1 (each within the scatter of the next); then compound 2.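

In this assay, the swap at the amide nitrogen removes the amide hydrogen, the one hydrogen-bond donor of ethylamino, with no readable change (a 1.1-fold higher number from compound 3 to compound 4 (0.04 log units; within the scatter)). Dimethylamino on the carbonyl carbon also cannot be told apart from methoxy (a 1.1-fold lower number from compound 1 to compound 4 (0.02 log units; within the scatter)), yet it stands clearly apart from benzyloxy (a 3.9-fold lower number from compound 2 to compound 4 (0.59 log units; beyond the scatter)). Nothing measured here explains these results. Open, as far as these compounds go, is whether a carboxylic acid or a cyclic amine such as morpholine on this carbonyl carbon would leave this level, and whether a longer chain on the amide nitrogen would approach the benzyloxy result.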